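The source may report more compounds than this note shows. Statements on the series, on what has been measured and on what is new or still open speak of the compounds shown alone.

Series notes. Compound 1 `Cc1cccc2c(NCc3ccco3)nc(NC(C)C)nc12` carries a methyl on the shared core, and compound 3 `COc1cccc2c(NCc3ccco3)nc(NC(C)C)nc12` carries a methoxy in its place. In a physicochemical assay for solubility, at pH 2 (on this read-out lower numbers stand for lower solubility and higher numbers for higher solubility), compound 1 gives >= 30000 nM, a limit of the assay rather than a number. Compound 3 likewise gives >= 30000 nM, again a limit. The change methoxy in place of methyl on an aromatic carbon thus yields a step that the two limits leave unreadable from compound 1 to compound 3; (the limit of >= 30000 nM in this assay, at which 3 of the 3 values shown sit). Compound 2 `Cc1ccc2nc(NC(C)C)nc(NCc3ccco3)c2c1` has the same atoms as compound 1 joined differently; the difference between the two cores is not broken down here. In this assay compound 2 gives >= 30000 nM, a limit. Compound 4 `COc1ccc2nc(NC(C)C)nc(NCc3ccco3)c2c1` is not yet measured and arises from compound 2 by methoxy in place of methyl on an aromatic carbon, the same kind of change, the place now being meta to a fused ring and para to a fused ring rather than ortho to a fused ring and meta to a fused ring. Given that compound 2 sits at >= 30000 nM, the step that the limit leaves unreadable from compound 2 to compound 4 is expected to be small, resting on (the limit of >= 30000 nM in this assay, at which 3 of the 3 values shown sit). Compound 4 is expected at 40000 nM, most likely reported as a limit again.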

Compound 4, solubility: >= 30000 nM
Compound 4: no number, only a limit (the forecaster's own chance of this, stated with the estimate: 80%); the middle value lies beyond the limit too.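

In this assay, going by these compounds alone, compound 4 gives >= 30000 nM, a limit, so no step from compound 2, itself at a limit, can be read. Going by these compounds, how far any of the four compounds lies past that limit, and whether methoxy in place of methyl shifts the read-out at either place, stays open.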